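A few compounds are considered here, and "the series" means these few. Any claim that something is new, unique, unknown or untested is made for them only; others in the source may bear on it.

Of the compounds shown here, three sharing one core have been tested in a functional assay for antagonist activity at transient receptor potential cation channel subfamily V member 1 (Homo sapiens), read by FLIPR and calcium flux; on this read-out lower numbers stand for stronger inhibition and higher numbers for weaker inhibition. Compound 1 `O=C1COc2ccc(NC(=O)C3CCN(c4ccccc4Br)CC3)cc2N1` gives 160 nM in this assay, the second highest of the three numbers. Compound 2 `O=C1COc2ccc(NC(=O)C3CCN(c4cccc(Cl)c4)CC3)cc2N1` gives 190 nM, and a 1.2-fold higher number from compound 1 to compound 2 (0.07 log units; within the scatter) lies within the scatter, so these two cannot be told apart. Compound 3 `O=C1COc2ccc(NC(=O)C3CCN(c4cc(F)c(F)c(F)c4)CC3)cc2N1` gives 59 nM; here a 2.7-fold lower number from compound 1 to compound 3 (0.43 log units; beyond the scatter) and a 3.2-fold lower number from compound 2 to compound 3 (0.51 log units; beyond the scatter) are both modest but real steps toward stronger inhibition.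

Compound 4 `CC(C)c1ccccc1N1CCC(C(=O)Nc2ccc3c(c2)NC(=O)CO3)CC1` has not yet been measured. It differs from compound 1 by isopropyl in place of bromo on an aromatic carbon. Going by the values given here, none of the measured steps exchanges bromo for isopropyl at this place, so no direct guide exists. The closest comparison is a 1.2-fold higher number from compound 1 to compound 2 (0.07 log units; within the scatter), where a different halogen pattern on the same ring left the number within the scatter, while a 2.7-fold lower number from compound 1 to compound 3 (0.43 log units; beyond the scatter) shows that a changed substitution pattern on this ring can shift the result modestly. Among the compounds with values here, with no step that speaks directly to an isopropyl group, the expectation for compound 4 is a step no larger than the scatter in either direction, written as a 1.3-fold higher number from compound 1 to compound 4 (0.10 log units; within the scatter). The estimate for compound 4 is 200 nM, with a range from 70 nM to 600 nM.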

Compound 4, half-maximal inhibitory concentration: 180 nM
The estimate for compound 4 lay 1.1-fold (0.05 log units) above the measured number, and the stated range covers the measured number.
By their numbers in this assay, from the lowest: compound 3; then compounds 1, 4 and 2 (each within the scatter of the next).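

In this assay, replacing bromo, a single heavy atom, with isopropyl, which has three carbon atoms, on an aromatic carbon ortho to a large group gives a 1.1-fold higher number from compound 1 to compound 4 (0.05 log units; within the scatter), so this larger group leaves the number where it was. Compound 4 also cannot be told apart from the compound carrying 3-chlorophenyl, with a 1.1-fold lower number from compound 2 to compound 4 (0.02 log units; within the scatter), but it stands apart from the compound carrying 3,4,5-trifluorophenyl, with a 3.1-fold higher number from compound 3 to compound 4 (0.48 log units; beyond the scatter), which leaves compound 3 as the only one of the four whose number is clearly separate from the rest. Nothing available explains why the bromo and isopropyl compounds read alike.

The compounds shown place only halogens and isopropyl on this ring, so it remains open whether this position would accept a group of a different kind, such as a methoxy group, an amine or a carboxylic acid, equally well. From the compounds shown here alone, it is also open whether isopropyl would give a similar number on a ring that also carries the fluoro groups of compound 3.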